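From methoxy to hydroxy in compound 1

The compounds below may be only part of what the source reports. "The series", "measured", "known", "first", "only" and "open" are said of these compounds alone.

Measured so far in an ADME assay on MRC5 cells (Homo sapiens) for inhibition, with a stated time of 72 h; a higher number here means that more compound is needed for the effect, a lower number that less compound is needed:
Compound 1 `COc1cccc(OC)c1C(=O)Nc1c[nH]nc1C(=O)N[C@H]1CC[C@H](OC)CC1` gives 31000 nM
Compound 2 `CCc1ccccc1C(=O)Nc1c[nH]nc1C(=O)N[C@H]1CC[C@H](OC)CC1` gives 3400 nM
Compound 3 `CO[C@H]1CC[C@H](NC(=O)c2n[nH]cc2NC(=O)c2ncoc2-c2ccccc2)CC1` gives 28000 nM

Compound 1 and compound 3 lie within the usual scatter of each other at the high end of these three numbers, while compound 2 needs clearly less compound to reach the effect.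

The next compound, compound 4 `COc1cccc(OC)c1C(=O)Nc1c[nH]nc1C(=O)N[C@H]1CC[C@H](O)CC1`, keeps the core of compound 1 and differs in one place: hydrogen in place of methyl on an oxygen on a saturated carbon. This is hydrogen in place of methyl on an oxygen on a saturated carbon, which turns 4-methoxycyclohexyl to 4-hydroxycyclohexyl. Among the measured compounds shown here, all three measured compounds carry the 4-methoxycyclohexyl group, so no pair of them shows this change and the data give it no measured size.

The expectation in this assay therefore starts from compound 1 at 31000 nM and is only a guess as to direction: a modest move towards a higher number, possibly none beyond the scatter. The estimated step is a 1.3-fold higher number from compound 1 to compound 4 (0.11 log units; within the scatter) and remains an expectation until it is tested. Compound 4 is expected at 40000 nM with an estimated range from 18000 nM to 90000 nM in this measurement.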

Compound 4, half-maximal effective concentration: 34000 nM
Compound 4: the middle estimate sits 1.2-fold (0.07 log units) above what was measured, within the range that was stated.
By their numbers in this assay, from the lowest: compound 2; then compounds 3, 1 and 4 (each within the scatter of the next).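

In this assay, among the compounds shown here, the swap of hydrogen for methyl on an oxygen on a saturated carbon now has a measured size, a 1.1-fold higher number from compound 1 to compound 4 (0.04 log units; within the scatter) and thus no change that can be told from the usual scatter; the earlier compounds all carried the 4-methoxycyclohexyl group and could not show this. On the core of compound 1, 4-methoxycyclohexyl and 4-hydroxycyclohexyl therefore read alike in this assay, although this single pair says nothing about the same swap on any other core. Nothing shown here accounts for this result, and it stands without an explanation.

From the compounds shown here alone, it remains open whether this place stays as flat with groups further from methoxy and hydroxy, such as an amine or a carboxylic acid in place of the hydroxy, or a longer chain on the oxygen. Also open, going by these compounds, is whether 4-hydroxycyclohexyl would read the same alongside the 2-ethylphenyl amide of compound 2, which stands at 3400 nM in this assay, far from the level shared by the other compounds.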